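Removing the Methyl from the Linking Nitrogen of Compound 3

The source may report more compounds than this note shows. Statements on the series, on what has been measured and on what is new or still open speak of the compounds shown alone.

Compound 3 `CN(c1ccc(Oc2ncnc3sccc23)cc1)c1nccc(N2CCCCC2)n1` gives 8790 nM in a functional assay on A549 cells (Homo sapiens) for inhibition, read by MTT assay, with a stated time of 72 h (on this read-out higher numbers stand for weaker inhibition and lower numbers for stronger inhibition), the second highest of the three numbers gathered so far. Its nearest neighbour is compound 2 `CN(c1ccc(Oc2ncnc3sccc23)cc1)c1nccc(N2CCc3ccccc3C2)n1`, which gives 6390 nM; the step of a 1.4-fold higher number from compound 2 to compound 3 (0.14 log units; within the scatter) lies within the scatter. Compound 1 `CN(C)c1ccc(C(=O)Nc2ccc(Oc3ncnc4ccsc34)cc2)cc1` gives 20200 nM, the highest of the set. Compound 4 `c1cc(N2CCCCC2)nc(Nc2ccc(Oc3ncnc4sccc34)cc2)n1` differs from compound 3 by hydrogen in place of methyl on a nitrogen on an aromatic ring. Among the compounds with values here, no measured step touches this nitrogen, so nothing among the three compounds bears directly on the change; the only comparison available, between the two ring substituents of compound 2 and compound 3, moved the number within the scatter. Compound 4 is therefore expected to show no step beyond the scatter, a 1.1-fold lower number from compound 3 to compound 4 (0.04 log units; within the scatter), with wide allowance in either direction. The estimate for compound 4 is 8000 nM, between 2500 nM and 25000 nM.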

Compound 4, half-maximal inhibitory concentration: 4020 nM
Compound 4: middle estimate off by 2.0-fold (0.30 log units), on the high side; measured number inside the range.
By their numbers in this assay, from the lowest: compounds 4, 2 and 3 (each within the scatter of the next, the first and the last beyond it); then compound 1.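

In this assay the nitrogen on an aromatic ring proves responsive: hydrogen in place of methyl gives a modest step (a 2.2-fold lower number from compound 3 to compound 4 (0.34 log units; beyond the scatter)) beyond the scatter. Within the data shown here, the earlier step at the ring substituent (a 1.4-fold higher number from compound 2 to compound 3 (0.14 log units; within the scatter)) stayed within the scatter, so this is the first single change here to pass it. Nothing available on these compounds accounts for the step.

As far as these compounds go, whether an ethyl or an acetyl on this nitrogen would move the number stays open. So does whether hydrogen there gives a like step alongside the 1,2,3,4-tetrahydroisoquinolin-2-yl of compound 2.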